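A Methoxy Group Added to Compound 3

A few compounds are considered here, and "the series" means these few. Any claim that something is new, unique, unknown or untested is made for them only; others in the source may bear on it.

Of the compounds shown here, three sharing one core have been measured in a functional assay on MOLT-4 cells (Homo sapiens) for inhibition, read by MTT assay, with a stated time of 48 h; on this read-out higher numbers stand for weaker inhibition and lower numbers for stronger inhibition. Compound 1 `CC(C)CCn1cc(/C=C/C(=O)CC(=O)C(=O)O)c2ccccc21` gives 20000 nM, compound 2 `O=C(/C=C/c1cn(-c2ccc(Cl)cc2)c2ccccc12)CC(=O)C(=O)O` gives 27000 nM, and compound 3 `O=C(/C=C/c1cn(Cc2ccccc2)c2ccccc12)CC(=O)C(=O)O` gives 15000 nM. Compound 3 stands within the scatter of both others, as shown by a 1.3-fold lower number from compound 1 to compound 3 (0.12 log units; within the scatter) and a 1.8-fold lower number from compound 2 to compound 3 (0.26 log units; within the scatter). The remaining step, a 1.4-fold higher number from compound 1 to compound 2 (0.13 log units; within the scatter), also stays within the scatter.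

Compound 4 `COc1ccc(Cn2cc(/C=C/C(=O)CC(=O)C(=O)O)c3ccccc32)cc1` differs from compound 3 by one change: methoxy in place of hydrogen on an aromatic carbon. This is methoxy in place of hydrogen on an aromatic carbon, so benzyl becomes 4-methoxybenzyl. Within the data shown here, no measured step makes this exact change, so the evidence is indirect. The closest guide is the exchange of the whole group on the aromatic nitrogen in compound 3, which gave a 1.8-fold lower number from compound 2 to compound 3 (0.26 log units; within the scatter). On that basis, no step beyond the scatter is expected in this assay. The expected step is a 1.1-fold lower number from compound 3 to compound 4 (0.03 log units; within the scatter). Compound 4 is estimated to give 14000 nM, within an expected range of 7000 nM to 28000 nM.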

Compound 4, half-maximal inhibitory concentration: > 40000 nM
Compound 4 ended at the assay's limit; the forecaster's own chance of this, stated with the estimate: 5%; middle value at least 2.8-fold (0.45 log units) from the limit.
By their numbers in this assay, from the lowest: compounds 3, 1 and 2 (each within the scatter of the next). At a limit, above all of these: compound 4.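

In this assay compound 4 gives > 40000 nM, which is a limit of the assay and not a number: the limit of > 40000 nM in this assay, at which 1 of the 4 values shown sits.

Even so, the step is readable as an at least 2.6-fold higher number from compound 3 to compound 4 (0.42 log units; beyond the scatter), so methoxy on this aromatic carbon, a change of 2 heavy atoms, goes beyond the scatter, as no exchange of the whole group on the aromatic nitrogen among compound 1, compound 2 and compound 3 did. The two other new steps, an at least 1.4-fold higher number from compound 2 to compound 4 (0.17 log units; that floor lies within the scatter) and an at least 2.0-fold higher number from compound 1 to compound 4 (0.30 log units; that floor lies within the scatter), give only floors, so neither separates its pair.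

From the compounds shown here alone, how far the number for compound 4 lies past the limit stays open. Among these compounds, no compound with a fluorine, a hydroxyl or an amine on the same carbon has been measured. The data do not tell whether a step of this size is special to methoxy.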